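Estimating permeability after a biaryl swap at the core

This account rests on a few compounds, and the source may have more. Where it says the series, first, only, none or still open, it means among the compounds named here.

Measured compounds:
- compound 1, `COc1cccc(CNCCCNc2ccnc3cc(Oc4ccccc4)ccc23)c1O`: 317 10^-6 cm/s
- compound 2, `COc1cccc(CNCCCNc2ccnc3cc(Cc4ccc(F)cc4)ccc23)c1O`: 23 10^-6 cm/s
- compound 3, `COc1cccc(CNCCCNc2ccnc3cc(Cc4ccc(F)cc4Cl)ccc23)c1O`: 23 10^-6 cm/s

In an ADME assay for permeability, using PAMPA, with a stated time of 30 min, at pH 7.4 (on this read-out lower numbers stand for lower permeability and higher numbers for higher permeability), compound 3 gives 23 10^-6 cm/s. It stands level with compound 2, since no change at the digits printed from compound 2 to compound 3 (within the scatter), and the two share the lowest numbers of the three; compound 1 sits far above, with a 14-fold lower number from compound 1 to compound 3 (1.14 log units; beyond the scatter).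

Compound 4, `COc1cccc(CNCCCNc2ccnc3cc(-c4ccc(C(C)(C)C)cc4)ccc23)c1O`, has not been measured. It differs from compound 3 at the same aromatic carbon of the shared core: 4-(tert-butyl)phenyl in place of 2-chloro-4-fluorobenzyl on an aromatic carbon.

Among the compounds with values here, no measured step covers a change of this kind. The steps that come nearest are a 14-fold lower number from compound 1 to compound 2 (1.14 log units; beyond the scatter) and a 14-fold lower number from compound 1 to compound 3 (1.14 log units; beyond the scatter), which show that a replacement at this carbon can move this assay by a large amount, while no change at the digits printed from compound 2 to compound 3 (within the scatter) shows that adding chloro on the benzyl ring left it unchanged. With nothing that directly matches a 4-(tert-butyl)phenyl group, the expectation is anchored on the benzyl pair rather than on compound 1, and the expected step is a 1.3-fold higher number from compound 3 to compound 4 (0.12 log units; within the scatter), judged to lie within the scatter. Compound 4 is therefore estimated at 30 10^-6 cm/s in this assay, with a range from 8 10^-6 cm/s to 120 10^-6 cm/s.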

Compound 4, apparent permeability: 237 10^-6 cm/s
Compound 4: the middle estimate sits 7.9-fold (0.90 log units) below what was measured; the whole stated range lies below it.
By their numbers in this assay, from the lowest: compounds 2 and 3 (each within the scatter of the next); then compounds 4 and 1 (each within the scatter of the next).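

At this aromatic carbon of the shared core, this assay separates 4-(tert-butyl)phenyl sharply from both benzyl groups, with a 10-fold higher number from compound 3 to compound 4 (1.01 log units; beyond the scatter) and a 10-fold higher number from compound 2 to compound 4 (1.01 log units; beyond the scatter) (both large and beyond the scatter). Against phenoxy, the same group gives a 1.3-fold lower number from compound 1 to compound 4 (0.13 log units; within the scatter) (within the scatter), so the four compounds now fall into two clear pairs: compounds 2 and 3 with the benzyl groups at the low end, and compounds 1 and 4 together at the high end. The large step from compound 3 to compound 4 also comes with little change in the simple counts: the group that leaves and the group that enters each hold one six-membered aromatic ring of carbon only and no hydrogen-bond donors or acceptors, and they differ by a single heavy atom.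

No measurement shown here explains why the compounds split into these two pairs. Going by these compounds, it also remains open whether an amine or a carboxylic acid in place of the tert-butyl group, or a longer chain at this same carbon, would sit with the higher pair or the lower one.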